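This account rests on a few compounds, and the source may have more. Where it says the series, first, only, none or still open, it means among the compounds named here.

Measured in a functional assay on A549 cells (Homo sapiens) for antiproliferative activity, read by MTT assay, with a stated time of 72 h; a lower number here means a stronger inhibitor, a higher number a weaker inhibitor:
- compound 1, `CCCCCCCCCCNC[C@@H]1OC[C@H](N)[C@@H]1O`: 47800 nM
- compound 2, `CCCCCCCCNC[C@@H]1OC[C@H](N)[C@@H]1O`: > 128000 nM, which is a limit of this assay and not a number
- compound 3, `CCCCCCCCNC[C@@H]1OC[C@H](N)[C@H]1O`: 71800 nM

Compound 2 and compound 3 share all atoms and bonds; their cores differ only in the way set out in the two compounds have the same atoms and bonds and differ only in configuration as drawn: 1 of 3 stereo elements differ; a stereocentre at a saturated ring carbon is drawn S in compound 2 and R in compound 3. The step is an at least 1.7-fold lower number from compound 2 to compound 3 (0.25 log units; that floor lies within the scatter), a floor that sits within the scatter, so no order between the two is claimed.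

Compound 1 carries, on the core of compound 2, the change (ethyl in place of hydrogen on a saturated chain carbon, eight bonds along the chain from an amine nitrogen). The step is an at least 2.6-fold lower number from compound 2 to compound 1 (0.42 log units; beyond the scatter); it is given only as a floor due to the limit of > 128000 nM in this assay, at which 1 of the 3 values shown sits.

Compound 4, `CCCCCCCCCCNC[C@@H]1OC[C@H](N)[C@H]1O`, has not yet been measured in this assay. It carries on the core of compound 3 the change (ethyl in place of hydrogen on a saturated chain carbon, eight bonds along the chain from an amine nitrogen). The place is the same word for word as in the change from compound 2 to compound 1, so this is the same change, made a second time among the compounds here.

The step from compound 3 to compound 4 in this assay is expected to be a 2.6-fold lower number from compound 3 to compound 4 (0.41 log units; beyond the scatter), roughly the size seen for compound 1, which rests on an at least 2.6-fold lower number from compound 2 to compound 1 (0.42 log units; beyond the scatter) and on the value of compound 3, 71800 nM. Compound 4 is therefore estimated at 28000 nM, with the expected range running from 11000 nM to 70000 nM.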

Compound 4, half-maximal inhibitory concentration: > 128000 nM
Compound 4: a limit, no number; the forecaster's own chance of this, stated with the estimate: 5%; middle value at least 4.5-fold (0.66 log units) away from the limit.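

In this assay compound 4 gives > 128000 nM, which is a limit of the assay and not a number. The same ethyl-for-hydrogen change reads on this core as an at least 1.7-fold higher number from compound 3 to compound 4 (0.25 log units; that floor lies within the scatter), so no order is claimed within that pair, yet the change does not carry over unchanged from one core to the other: the same change on two cores in this assay, an at least 2.6-fold lower number (0.42 log units; beyond the scatter) from compound 2 to compound 1 and an at least 1.7-fold higher number (0.25 log units; that floor lies within the scatter) from compound 3 to compound 4, at least 4.7-fold (0.67 log units) apart, beyond the scatter of two such steps The configuration pair reads as an at least 2.6-fold higher number from compound 1 to compound 4 (0.42 log units; beyond the scatter), which shows that in these pairs the outcome of the change goes with the drawn configuration at one saturated ring carbon, but does not show the true size of any of these steps, all of which are floors, nor any rule beyond these two cores: the limit of > 128000 nM in this assay, at which 2 of the 4 values shown sit.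

Compound 2 and compound 4 both stand at the limit, so they cannot be compared with each other. Still open, on these data alone, is how a dodecyl chain, or a carboxylic acid on the chain, would read on either core in this assay.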